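This account rests on a few compounds, and the source may have more. Where it says the series, first, only, none or still open, it means among the compounds named here.

Measured in an ADME assay on the whole organism (plasma, strain BALB/c) for pharmacokinetics, with Mus musculus as the target, at a dose of 5 mg/kg by the oral route; on this read-out higher numbers stand for higher exposure at the dose given and lower numbers for lower exposure:

- Compound 1 `CN(C)S(=O)(=O)c1ccc(F)c(C#Cc2cc(Cl)ccc2OCC(=O)O)c1`: 4880 ng.h/mL
- Compound 2 `CC(C)S(=O)(=O)c1ccc(Cl)c(C#Cc2cc(Cl)ccc2OCC(=O)O)c1`: 4890 ng.h/mL
- Compound 3 `COCCNS(=O)(=O)c1ccc(C)c(C#Cc2cc(Cl)ccc2OCC(=O)O)c1`: 831 ng.h/mL

Compound 3, at 831 ng.h/mL, has the lowest of the three numbers. Compound 1 and compound 2 both lie beyond the scatter from it and within the scatter of each other.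

Compound 4 `Cc1ccc(S(=O)(=O)N2CCOCC2)cc1C#Cc1cc(Cl)ccc1OCC(=O)O` carries morpholin-4-yl in place of (2-methoxyethyl)amino on a sulfonyl sulfur. Among the measured compounds shown here, no two measured compounds differ in one place only, so this step has no direct precedent in this assay. Like compound 4, compound 1 has no sulfonamide hydrogen and gives 4880 ng.h/mL, and this is the basis for expecting a rise beyond the scatter. Compound 1 also differs from compound 3 elsewhere, so only part of that gap is expected to carry over. The expected change is a 3.0-fold higher number from compound 3 to compound 4 (0.48 log units; beyond the scatter). For compound 4 the estimated value is 2500 ng.h/mL, with an expected range of 900 ng.h/mL to 7000 ng.h/mL.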

Compound 4, area under the concentration-time curve: 1230 ng.h/mL
Estimate against measurement, compound 4: 2.0-fold (0.31 log units) above, within the range that was stated.
By their numbers in this assay, from the lowest: compounds 3 and 4 (each within the scatter of the next); then compounds 1 and 2 (each within the scatter of the next).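

In this assay, placing morpholin-4-yl instead of (2-methoxyethyl)amino on the sulfonyl sulfur gives a 1.5-fold higher number from compound 3 to compound 4 (0.17 log units; within the scatter). Among the compounds shown here, this is the first direct reading at this position: with the rest of the molecule kept, the change removes the sulfonamide hydrogen and adds a six-membered non-aromatic ring, yet it does not separate the two compounds in this assay. No measurement at hand accounts for this result.

As far as these compounds go, compound 1 and compound 2 each differ from compound 3 and compound 4 in more than one place, so it remains open whether their higher numbers belong to the group on the sulfonyl sulfur or to another part of the molecule. From the compounds shown here alone, it also remains open how a piperidin-1-yl or an unsubstituted amino group on that sulfur would read on the core of compound 4.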